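Swapping bromo for methoxy on a carboxylic acid analogue

A few compounds are considered here, and "the series" means these few. Any claim that something is new, unique, unknown or untested is made for them only; others in the source may bear on it.

Compound 1 `COC(=O)C(Nc1cc(CS(=O)(=O)/C=C/c2c(OC)cc(OC)cc2OC)ccc1OC)c1ccc(Br)cc1` gives 200 nM in a functional assay on K562 cells (Homo sapiens) for cytotoxicity, read by trypan blue exclusion, with a stated time of 96 h; a higher number here means a weaker inhibitor, a lower number a stronger inhibitor. Compound 2 `COC(=O)C(Nc1cc(CS(=O)(=O)/C=C/c2c(OC)cc(OC)cc2OC)ccc1OC)c1ccc(OC)cc1`, which differs by methoxy in place of bromo on an aromatic carbon, gives 150 nM, so this assay records a 1.3-fold lower number from compound 1 to compound 2 (0.12 log units; within the scatter). Compound 3 `COc1cc(OC)c(/C=C/S(=O)(=O)Cc2ccc(OC)c(NC(C(=O)O)c3ccc(Br)cc3)c2)c(OC)c1` differs from compound 1 by hydrogen in place of methyl on an oxygen next to a carbonyl group. Compound 3 gives 200 nM, with no change at the digits printed from compound 1 to compound 3 (within the scatter). Compound 4 `COc1ccc(C(Nc2cc(CS(=O)(=O)/C=C/c3c(OC)cc(OC)cc3OC)ccc2OC)C(=O)O)cc1` stands to compound 3 as compound 2 stands to compound 1: it differs by methoxy in place of bromo on an aromatic carbon, the same change as before, occurring twice among these four compounds. For compound 4 the expected step is a 1.3-fold lower number from compound 3 to compound 4 (0.10 log units; within the scatter), resting on the earlier change because compound 2 gave a 1.3-fold lower number from compound 1 to compound 2 (0.12 log units; within the scatter) against compound 1. Compound 4 is therefore expected to give about 160 nM, with an estimated range from 80 nM to 320 nM.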

Compound 4, half-maximal inhibitory concentration: 15 nM
The estimate for compound 4 lay 11-fold (1.03 log units) above the measured number; measured number outside the range, below it.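

In this assay methoxy in place of bromo on the acid gives a 13-fold lower number from compound 3 to compound 4 (1.12 log units; beyond the scatter) and hydrogen in place of methyl on the methoxy-bearing ester gives a 10-fold lower number from compound 2 to compound 4 (1.00 log units; beyond the scatter) while the two changes made together give a 13-fold lower number from compound 1 to compound 4 (1.12 log units; beyond the scatter). The swap of bromo for methoxy did not carry over from one core to the other: the same change on two cores in this assay, a 1.3-fold lower number (0.12 log units; within the scatter) from compound 1 to compound 2 and a 13-fold lower number (1.12 log units; beyond the scatter) from compound 3 to compound 4, 10-fold (1.00 log units) apart, beyond the scatter of two such steps. The change from ester to acid did not carry over either, so in these four compounds the size of each change depends on the other, though this does not show why or whether it holds beyond them: the same change on two cores in this assay, no change at the digits printed (within the scatter) from compound 1 to compound 3 and a 10-fold lower number (1.00 log units; beyond the scatter) from compound 2 to compound 4, 10-fold (1.00 log units) apart, beyond the scatter of two such steps.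

Going by these compounds, it remains open whether a chloro, methyl or hydroxy group in place of bromo or methoxy would also pair with the acid in this way. On these data alone, it is equally open whether an amide in place of the acid would keep the low number of compound 4.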